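The source may hold more compounds than are shown below. What is called first, only, known or untested is meant among the compounds shown, and "the series" means these compounds.

Three compounds share one core and differ only in the group carried on a six-membered aromatic ring of carbon only. Compound 1 `Cn1nc2c(=O)n(CC3(O)CCN(Cc4ccc(-c5ccco5)cc4Cl)CC3)cnc2c1-c1ccc(CO)cc1` carries hydroxymethyl there, and in an assay on isolated protein for inhibition of ubiquitin carboxyl-terminal hydrolase 7 (Homo sapiens), with stated times of 30 min and 2 h (on this read-out lower numbers stand for stronger inhibition and higher numbers for weaker inhibition), compound 1 gives 42.5 nM. Compound 2 `Cn1nc2c(=O)n(CC3(O)CCN(Cc4ccc(-c5ccco5)cc4Cl)CC3)cnc2c1-c1ccc(CNS(C)(=O)=O)cc1` carries (methanesulfonamido)methyl, and in this assay compound 2 gives 65.3 nM. Compound 3 `Cn1nc2c(=O)n(CC3(O)CCN(Cc4ccc(-c5ccco5)cc4Cl)CC3)cnc2c1-c1ccc(F)cc1` carries fluoro, and in this assay compound 3 gives 64.5 nM, the second highest of the three numbers; the steps that lead to it are a 1.5-fold higher number from compound 1 to compound 3 (0.18 log units; within the scatter) and a 1.0-fold lower number from compound 2 to compound 3 (0.01 log units; within the scatter), so all three stand close together.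

Compound 4 `CC(=O)NCc1ccc(-c2c3ncn(CC4(O)CCN(Cc5ccc(-c6ccco6)cc5Cl)CC4)c(=O)c3nn2C)cc1` has not yet been measured. It differs from compound 3 at one point: acetamidomethyl in place of fluoro on an aromatic carbon. The steps already seen at this place are the guide: a 1.5-fold higher number from compound 1 to compound 2 (0.19 log units; within the scatter), a 1.5-fold higher number from compound 1 to compound 3 (0.18 log units; within the scatter) and a 1.0-fold lower number from compound 2 to compound 3 (0.01 log units; within the scatter). Each exchange among hydroxymethyl, (methanesulfonamido)methyl and fluoro left the number within the scatter, so this position has so far tolerated small and larger groups alike. On that basis no step beyond the scatter is expected when acetamidomethyl takes the place of fluoro. The expected step is a 1.2-fold lower number from compound 3 to compound 4 (0.07 log units; within the scatter). Compound 4 is therefore estimated to give about 55 nM, with a likely range from 25 nM to 120 nM.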

Compound 4, half-maximal inhibitory concentration: 46.1 nM
Beside the measured number, compound 4's estimate is 1.2-fold (0.08 log units) above it, within the range that was stated.
By their numbers in this assay, from the lowest: compounds 1, 4, 3 and 2 (each within the scatter of the next).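

In this assay, exchanging fluoro for acetamidomethyl puts 5 heavy atoms, including a hydrogen-bond donor and a hydrogen-bond acceptor, where 1 heavy atom stood, yet the number stays within the scatter (a 1.4-fold lower number from compound 3 to compound 4 (0.15 log units; within the scatter)), so a 4-(acetamidomethyl)phenyl group is tolerated here as well as a 4-fluorophenyl group. The new compound also allows changes at the far end of the chain to be compared: acetyl in place of methylsulfonyl on the amine nitrogen (a 1.4-fold lower number from compound 2 to compound 4 (0.15 log units; within the scatter)) and acetamido in place of hydroxy on the saturated chain carbon (a 1.1-fold higher number from compound 1 to compound 4 (0.04 log units; within the scatter)) both stay within the scatter, so among these compounds neither the amide, the sulfonamide nor the alcohol stands apart. No measurement at hand gives a reason why these exchanges leave the number so little changed.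

The compounds shown leave open whether an aminomethyl group, a carboxylic acid or a longer chain at this place would also stay within the scatter. As far as these compounds go, all four share the rest of the structure, so it also remains open whether this tolerance would hold with a different group elsewhere on the shared core.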